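Bromo on the N-phenyl ring: no precedent in the series

This account rests on a few compounds, and the source may have more. Where it says the series, first, only, none or still open, it means among the compounds named here.

Compound 1 `CC(C)(C)c1cc(NC(=O)Nc2ccc(F)cc2)n(-c2ccccc2)n1` gives 7.4 degrees C in an assay on isolated protein for inhibition of STE20-like serine/threonine-protein kinase (Homo sapiens), read by thermal shift assay, tested at 10 uM; on this read-out lower numbers stand for weaker stabilisation of the target and higher numbers for stronger stabilisation of the target against heat. Compound 2 `COc1cccc(NC(=O)Nc2cc(C(C)(C)C)nn2-c2ccccc2)c1` gives 3.6 degrees C, and compound 3 `CC(C)(C)c1cc(NC(=O)Nc2cc(F)cc(F)c2)n(-c2ccccc2)n1` gives 3 degrees C, the lowest of the three, though its gap to compound 2 lies within the scatter, while a number 4.4 degrees C lower from compound 1 to compound 3 (beyond the scatter) and a number 3.8 degrees C lower from compound 1 to compound 2 (beyond the scatter) are clear. Compound 4 `CC(C)(C)c1cc(NC(=O)Nc2cc(F)cc(F)c2)n(-c2ccc(Br)cc2)n1` carries bromo in place of hydrogen on an aromatic carbon, the change reading phenyl to 4-bromophenyl. Among the measured compounds shown here, every measured step concerns the aryl on the amide-type nitrogen; no step touches the ring changed here, so nothing bears directly on it. The step is therefore expected to fall within the scatter, a number 0.20 degrees C higher from compound 3 to compound 4 (within the scatter), in no set direction. Compound 4 is estimated at 3.2 degrees C, between 0.5 degrees C and 6.5 degrees C.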

Compound 4, shift of the target's melting temperature: 0.5 degrees C
Compound 4: middle estimate off by 2.7 degrees C, on the high side; the measured number falls inside the stated range.
By their numbers in this assay, from the lowest: compound 4; then compounds 3 and 2 (each within the scatter of the next); then compound 1.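

Among the compounds shown here, the phenyl ring changed here, which no earlier step touched, does respond to substitution: a number 2.5 degrees C lower from compound 3 to compound 4 (beyond the scatter) in this assay. This holds with 3,5-difluorophenyl on the amide-type nitrogen, and it shows that bromo on this ring can lower the number. No measurement at hand accounts for the drop.

From the compounds shown here alone, whether the same change lowers the number with the 4-fluorophenyl of compound 1 remains open. So does whether chloro, methyl or an amine at this place would give a comparable step.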